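A few compounds are considered here, and "the series" means these few. Any claim that something is new, unique, unknown or untested is made for them only; others in the source may bear on it.

Of the compounds shown here, three have so far been tested in an in vitro functional assay on HEK ts201 cells for antagonist activity at Neuronal acetylcholine receptor; alpha4/beta2 (Homo sapiens), read by fluorescence and calcium flux; on this read-out lower numbers stand for stronger inhibition and higher numbers for weaker inhibition. Compound 1 `CC1CC(=O)N(c2ccccc2C(=O)OCC2CCCN(CCCCCc3ccccc3)C2)C1=O` gives 24500 nM. Compound 2 `CN1CCCC(COC(=O)c2ccccc2-c2ccccc2)C1` gives 6920 nM, and compound 3 `O=C(NCc1ccccc1-c1ccccc1)C1CCCN(CCCc2ccccc2)C1` gives 16600 nM. Among the measured compounds shown here, of these three numbers, the one for compound 1 is the highest. Its difference from compound 3 lies within the usual scatter of repeated measurements, so the two cannot be told apart, whereas its difference from compound 2 lies beyond the scatter, and compound 2 is the stronger inhibitor of that pair.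

The next compound to be measured is compound 4 `COc1ccc(OCCCCCN2CCCC(COC(=O)c3ccccc3N3C(=O)CC(C)C3=O)C2)cc1`. Compared with compound 1, the change is 4-methoxyphenoxy in place of phenyl on a saturated chain carbon, five bonds along the chain from an amine nitrogen in a ring. The remaining part of the molecule is kept as it is. For the measured compounds named here, none of the three measured compounds differ from one another in just this place, so the measured set gives no direct step to lean on for this exchange, and the starting point is a weak inhibitor.

On that basis the step of a 1.2-fold lower number from compound 1 to compound 4 (0.09 log units; within the scatter) is expected to be small, with no clear direction beyond the scatter. Compound 4 is therefore estimated to give 20000 nM in this assay, within a range from 6000 nM to 60000 nM.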

Compound 4, half-maximal inhibitory concentration: 14500 nM
Compound 4: middle estimate off by 1.4-fold (0.14 log units), on the high side; measured number inside the range.
By their numbers in this assay, from the lowest: compound 2; then compounds 4, 3 and 1 (each within the scatter of the next).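

In this assay, putting 4-methoxyphenoxy in place of phenyl on a saturated chain carbon, five bonds along the chain from an amine nitrogen in a ring, gives a 1.7-fold lower number from compound 1 to compound 4 (0.23 log units; within the scatter), so compound 1 and compound 4 cannot be told apart. Among the compounds shown here, this is the first direct reading at this place: a group with more heavy atoms, carrying hydrogen-bond acceptors where phenyl has none, leaves the number indistinguishable from that of compound 1, although this single step says nothing about other groups here or about other cores. No measurement at hand explains why this exchange produces no clear shift.

The exchange adds both a linking oxygen and a methoxy group in one step, so their separate contributions remain unresolved, and a plain phenoxy group would be the simplest way to tell them apart. On these data alone, whether a group of a different kind at this place, such as a carboxylic acid or a primary amine, would move the number beyond the scatter also stays open.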